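A Methoxy for a Trifluoromethyl at an Assay Limit

The source may hold more compounds than are shown below. What is called first, only, known or untested is meant among the compounds shown, and "the series" means these compounds.

Compound 1 `COc1ccc(-c2cn(C[C@H]3COC(C)(C)O3)nn2)cc1`: in a functional assay on B16 cells (Mus musculus) for cytotoxicity, read by MTT assay, with a stated time of 48 h (a higher number here means a weaker inhibitor, a lower number a stronger inhibitor), compound 1 gives > 100000 nM, which is a limit of the assay and not a number.
Compound 2 `Cc1ccc(-c2cn(Cc3ccccc3)nn2)cc1`: compound 2 gives > 100000 nM, again a limit.
Compound 3 `FC(F)(F)c1ccc(-c2cn(Cc3ccccc3)nn2)cc1`: compound 3 gives > 100000 nM, also a limit.

Compound 3 therefore stands only at the limit where all three measured values sit, as recorded in the limit of > 100000 nM in this assay, at which 3 of the 3 values shown sit. Among the compounds with values here, the single measured step that bears on the change, a step that the two limits leave unreadable from compound 2 to compound 3, is unreadable in size, since both of its ends are limits. Compound 4 `COc1ccc(-c2cn(Cc3ccccc3)nn2)cc1` differs from compound 3 by methoxy in place of trifluoromethyl on an aromatic carbon. With nothing readable to build on, no movement beyond the scatter is expected, and compound 4 is expected to report the same limit. The estimate for compound 4 is 150000 nM, ranging from 50000 nM to 500000 nM. The expected step is therefore a step that the limit leaves unreadable from compound 3 to compound 4.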

Compound 4, half-maximal inhibitory concentration: > 100000 nM
Compound 4: a limit, no number (the forecaster's own chance of this, stated with the estimate: 85%); the middle value does not contradict the limit.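

Compound 4 also sits at a limit and not a number, so no step linking it to compound 1, compound 2 or compound 3 can be read: the limit of > 100000 nM in this assay, at which 4 of the 4 values shown sit.

On these data alone, whether methoxy, methyl and trifluoromethyl differ at all on the shared core remains open.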